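Replacing Methyl with Chloro in Compound 3

The source may report more compounds than this note shows. Statements on the series, on what has been measured and on what is new or still open speak of the compounds shown alone.

In a functional assay on HeLa cells (Homo sapiens) for cytotoxicity, read by MTT assay, with a stated time of 48 h (on this read-out lower numbers stand for stronger inhibition and higher numbers for weaker inhibition), compound 1 `O=C(O)CN1C(=O)/C(=C/c2nc3ccccc3n2Cc2ccc(Br)cc2F)SC1=S` gives only a limit, > 50000 nM. Compound 2 `O=C(O)CN1C(=O)/C(=C/c2nc3ccccc3n2Cc2ccc([N+](=O)[O-])cc2)SC1=S` gives 18600 nM. Compound 3 `Cc1ccc(Cn2c(/C=C3\SC(=S)N(CC(=O)O)C3=O)nc3ccccc32)cc1` gives 1280 nM, the lowest of the numbers available. Compound 4 `O=C(O)CN1C(=O)/C(=C/c2nc3ccccc3n2Cc2ccc(Cl)cc2)SC1=S` carries chloro in place of methyl on an aromatic carbon, para to a large group: chloro in place of methyl on an aromatic carbon. For the measured compounds named here, no measured step makes this exact change, but two large ones bear on it: methyl in place of nitro gave a 15-fold lower number from compound 2 to compound 3 (1.16 log units; beyond the scatter), and 4-methylphenyl in place of 4-bromo-2-fluorophenyl gave an at least 39-fold lower number from compound 1 to compound 3 (1.59 log units; beyond the scatter). Losing the methyl is therefore expected to raise the number in this assay, though by less than either step. The expected change is a 3.5-fold higher number from compound 3 to compound 4 (0.55 log units; beyond the scatter). Compound 4 is estimated at 4500 nM, within an expected range of 1500 nM to 20000 nM.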

Compound 4, half-maximal inhibitory concentration: 8720 nM
The estimate for compound 4 lay 1.9-fold (0.29 log units) below the measured number, within the range that was stated.
By their numbers in this assay, from the lowest: compound 3; then compound 4; then compound 2. At a limit, above all of these: compound 1.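

For the compounds shown here, at this position, chloro does not match methyl: in this assay the change gives a 6.8-fold higher number from compound 3 to compound 4 (0.83 log units; beyond the scatter), the first direct reading of this swap. Chloro still outperforms nitro, with a 2.1-fold lower number from compound 2 to compound 4 (0.33 log units; beyond the scatter), so methyl, chloro and nitro now stand in that order, each gap beyond the scatter. Against the 4-bromo-2-fluorophenyl group of compound 1, the 4-chlorophenyl group gives an at least 5.7-fold lower number from compound 1 to compound 4 (0.75 log units; beyond the scatter), a step read from a limit: the limit of > 50000 nM in this assay, at which 1 of the 4 values shown sits.

As far as these compounds go, whether an amine, a methoxy group or a longer chain at this position would stay near compound 3 remains open. The compounds shown also do not separate the bromo from the fluoro of compound 1.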